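A few compounds are considered here, and "the series" means these few. Any claim that something is new, unique, unknown or untested is made for them only; others in the source may bear on it.

Compound 2, `COc1ccc(-c2csc(N)c2C(=O)OCc2ccccc2F)cc1OC`, stands highest of the two compounds measured in an assay on isolated protein for inhibition of protein kinase C zeta type (Homo sapiens), with stated times of 1 h and 2.5 min, tested at 30 uM (a higher number here means more inhibition at the concentration tested (going by the name of the read-out), a lower number less inhibition), where compound 2 gives 100%, while compound 1, `COc1ccc(-c2csc(N)c2C(=O)OCc2ccc(C)cc2)cc1OC`, gives 50%. For the measured compounds named here, the only step recorded, a number 50 percentage points higher from compound 1 to compound 2 (beyond the scatter), concerns the aromatic ring of the ester and not the carbonyl link. Compound 3, `COc1ccc(-c2csc(N)c2C(=O)NCc2ccccc2)cc1OC`, differs from compound 2 by benzylamino in place of (2-fluorobenzyl)oxy on a carbonyl carbon, a change without any measured precedent here. The expected step for compound 3 is therefore uncertain, estimated as a number 25 percentage points lower from compound 2 to compound 3 (beyond the scatter) in this assay. Compound 3 is estimated at 75%, between 40% and 100%.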

Compound 3, a percentage reported as inhibition, at one concentration (the size of the read-out at that concentration, not a potency): 43%
For compound 3 the middle estimate is 32 percentage points above the measured one, and the stated range covers the measured number.
By their numbers in this assay, from the lowest: compounds 3 and 1 (each within the scatter of the next); then compound 2.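

In this assay, the change on the carbonyl carbon itself gives a number 57 percentage points lower from compound 2 to compound 3 (beyond the scatter), so a replacement at this position can matter as much as a large step, at least from the (2-fluorobenzyl)oxy ester. Measured from the (4-methylbenzyl)oxy ester, the same kind of replacement gives a number 7 percentage points lower from compound 1 to compound 3 (within the scatter), so the outcome of moving to benzylamino depends on which ester it replaces. Nothing available explains either step.

The compounds shown leave open whether the large step follows the entering nitrogen or the leaving fluorine, as compound 3 differs from compound 2 in both. They also leave open how a 2-fluorobenzylamino group or a carboxylic acid on this carbonyl carbon would read in this assay.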